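Thiosemicarbazide series with two ring sizes: methyl step

The source may hold more compounds than are shown below. What is called first, only, known or untested is meant among the compounds shown, and "the series" means these compounds.

Measured compounds in a functional assay on A-375 cells (Homo sapiens) for cytotoxicity, read by MTT assay, with a stated time of 72 h, tested at 10 uM; a higher number here means more inhibition of growth at the concentration tested, a lower number less inhibition of growth:
compound 1, `N/C(=N\NC(=S)N1CCCCCC1)c1ccccn1`: 86.5%
compound 2, `N/C(=N\NC(=S)N1CCCCC1)c1ccccn1`: 85.8%
compound 3, `Cc1cccc(/C(N)=N/NC(=S)N2CCCCC2)n1`: 76.4%

Compound 1 and compound 2 give numbers within the scatter of each other; the difference between their two cores is not broken down here. Compound 3 differs from compound 2 by one change, (methyl in place of hydrogen on an aromatic carbon), and this change gave a number 9.4 percentage points lower from compound 2 to compound 3 (within the scatter), a step within the scatter.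

Compound 4, `Cc1cccc(/C(N)=N/NC(=S)N2CCCCCC2)n1`, is not yet measured in this assay. It differs from compound 1 by methyl in place of hydrogen on an aromatic carbon, the same kind of change as from compound 2 to compound 3, and the two place descriptions read word for word alike. Going by the values given here, the only measured instance of this change is the step from compound 2 to compound 3, so the expectation for compound 4 rests on that single step and on the value of compound 1.

Among the compounds with values here, for compound 4 a step of a number 8.5 percentage points lower from compound 1 to compound 4 (within the scatter) is expected, of about the same size as the one seen between compound 2 and compound 3. Compound 4 is therefore estimated at 78% in this assay, with a range from 66% to 90%.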

Compound 4, percent growth inhibition at one concentration: 79.9%
Compound 4: the middle estimate sits 1.9 percentage points below what was measured; the measured number falls inside the stated range.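

In this assay, methyl in place of hydrogen on an aromatic carbon gives a number 6.6 percentage points lower from compound 1 to compound 4 (within the scatter), and the step reads alike on the two cores: the same change on two cores in this assay, a number 9.4 percentage points lower (within the scatter) from compound 2 to compound 3 and a number 6.6 percentage points lower (within the scatter) from compound 1 to compound 4, 2.8 percentage points apart, within the scatter of two such steps.

The two pairs therefore give no sign that the core of compound 1 and the core of compound 2 treat this change differently, so the step carries across these two cores in this assay. Neither step lies beyond the scatter, however, so the pairs do not establish that the methyl alters growth inhibition in either direction, and two pairs read at a single concentration say nothing about any further core in the series.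

The compounds shown leave open whether another group at this place next to the ring nitrogen, such as ethyl, methoxy, chlorine or an amine, would give a step beyond the scatter. Also open, from the compounds shown here alone, is how a methyl on another carbon of the aromatic ring would read in this assay.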